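Working notes: 3-aminophenyl to 4-aminophenyl

A few compounds are considered here, and "the series" means these few. Any claim that something is new, unique, unknown or untested is made for them only; others in the source may bear on it.

Values so far in a functional assay on L1210 cells (Mus musculus) for antiproliferative activity, read by cell counting, with a stated time of 96 h; a higher number here means a weaker inhibitor, a lower number a stronger inhibitor
- compound 1 `COc1ccc(Oc2ccccc2NC(C)=C2C(=O)CC(c3ccccc3)CC2=O)cc1OC` gives 65 nM
- compound 2 `CC(Nc1ccccc1Oc1cccc(N)c1)=C1C(=O)CC(c2ccccc2)CC1=O` gives 53 nM

For the measured compounds named here, compound 2 stands within the scatter of compound 1, the only other measured compound, so the two cannot be ranked. Compound 3 `CC(Nc1ccccc1Oc1ccc(N)cc1)=C1C(=O)CC(c2ccccc2)CC1=O` keeps the shared core of compound 2 and carries 4-aminophenyl in place of 3-aminophenyl on an oxygen on an aromatic ring. Going by the values given here, no measured step moves the amino group, so the data hold no direct precedent. The nearest evidence is the exchange of 3,4-dimethoxyphenyl for 3-aminophenyl on that same oxygen, which gave only a small step (a 1.2-fold lower number from compound 1 to compound 2 (0.09 log units; within the scatter)). On that single step, no change beyond the scatter is expected in this assay, and neither direction is favoured. The expected step is small (a 1.0-fold higher number from compound 2 to compound 3 (0.02 log units; within the scatter)). For compound 3 the estimated value is 55 nM (expected range 22 nM to 140 nM).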

Compound 3, half-maximal inhibitory concentration: 40 nM
Compound 3: the middle estimate sits 1.4-fold (0.14 log units) above what was measured; measured number inside the range.
By their numbers in this assay, from the lowest: compounds 3, 2 and 1 (each within the scatter of the next).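

Working notes, continued. In this assay, for the compounds shown here, the exchange of 3-aminophenyl for 4-aminophenyl on an oxygen on an aromatic ring gives the first reading on where the amino group stands on that ring, and the step stays within the scatter (a 1.3-fold lower number from compound 2 to compound 3 (0.12 log units; within the scatter)). The wider exchange of 3,4-dimethoxyphenyl for 4-aminophenyl also stays within the scatter (a 1.6-fold lower number from compound 1 to compound 3 (0.21 log units; within the scatter)), so the three groups on this oxygen cannot be ranked in this assay, and neither the place of the amino group on the ring nor its presence in place of the two methoxy groups separates these compounds. No supporting measurement is available to explain these small steps.

Open questions remain about how far this position stays flat, since all three groups are substituted phenyl rings of similar size and none carries a carboxylic acid, a hydroxyl or a longer chain ending in an amine. The compounds shown also leave open whether an unsubstituted phenyl on this oxygen, or an acetamide in place of the free amino group, would give a step beyond the scatter.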